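The compounds below may be only part of what the source reports. "The series", "measured", "known", "first", "only" and "open" are said of these compounds alone.

Measured compounds in an ADME assay on Vero 76 cells (Chlorocebus sabaeus) for cytotoxicity, read by MTT assay, with a stated time of 96 h; a lower number here means that less compound is tolerated, a higher number that more compound is tolerated:
- compound 1 `Clc1ccc(NCc2cn(-c3ccccc3)nc2-c2ccc(Cl)cc2)cc1`: 90000 nM
- compound 2 `FC(F)(F)c1ccc(-c2nn(-c3ccccc3)cc2CNc2ccc(Br)cc2)cc1`: 17000 nM
- compound 3 `Cc1ccc(NCc2cn(-c3ccccc3)nc2-c2ccc(C(F)(F)F)cc2)cc1`: 82000 nM

Compound 3 stands second highest of the three in this assay; its value and that of compound 1 lie within the scatter, while compound 2 sits well lower. Compound 4 `FC(F)(F)c1ccc(-c2nn(-c3ccccc3)cc2CNc2ccc(Cl)cc2)cc1` differs from compound 3 by chloro in place of methyl on an aromatic carbon. Within the data shown here, no measured pair shows exactly this change. The nearest guide is a 4.8-fold higher number from compound 2 to compound 3 (0.68 log units; beyond the scatter), where bromo gave a clearly lower number than methyl at the same place. Chloro, another halogen at that place, is therefore expected to move the number downward from compound 3, by an estimated 1.8-fold lower number from compound 3 to compound 4 (0.26 log units; within the scatter), though with wide uncertainty. For compound 4 the expected value is 45000 nM, with a range from 15000 nM to 120000 nM.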

Compound 4, half-maximal cytotoxic concentration: 10000 nM
Beside the measured number, compound 4's estimate is 4.5-fold (0.65 log units) above it, and the stated range ends above it.
By their numbers in this assay, from the lowest: compounds 4 and 2 (each within the scatter of the next); then compounds 3 and 1 (each within the scatter of the next).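

In this assay, chloro in place of methyl gives an 8.2-fold lower number from compound 3 to compound 4 (0.91 log units; beyond the scatter), while chloro and bromo do not separate, with a 1.7-fold lower number from compound 2 to compound 4 (0.23 log units; within the scatter), so at this place both halogens sit well under methyl. A second place also counts: trifluoromethyl in place of chloro there gives a 9.0-fold lower number from compound 1 to compound 4 (0.95 log units; beyond the scatter). Nothing measured here explains these shifts. Going by these compounds, how an amine or a carboxylic acid would read at the first place stays open. So does whether a longer carbon chain would match methyl.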